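The source may report more compounds than this note shows. Statements on the series, on what has been measured and on what is new or still open speak of the compounds shown alone.

Compound 1, `Cc1cc2c(c(N)nn2C)c(=O)[nH]1`: 0%
Compound 2, `Cn1nc(N)c2c(=O)[nH]c(-c3ccccc3)cc21`: 6%

In an assay on isolated protein for inhibition of protein kinase C zeta type (Homo sapiens), read by mobility shift assay, tested at 30 uM (a higher number here means more inhibition at the concentration tested (going by the name of the read-out), a lower number less inhibition), compound 1 gives 0% and compound 2 gives 6%. Among the compounds with values here, the two stand together: the only measured step, a number 6 percentage points higher from compound 1 to compound 2 (within the scatter), lies within the scatter, so compound 2 is the larger of two numbers that cannot be told apart. Compound 3, `Cn1nc(N)c2c(=O)[nH]c(-c3ccccn3)cc21`, differs from compound 2 by pyridin-2-yl in place of phenyl on an aromatic carbon. Within the data shown here, no measured step involves a pyridin-2-yl, so nothing bears directly on this change; the one known step, a phenyl entering, stayed within the scatter. Compound 3 is therefore expected to show no step beyond the scatter, a number 1 percentage points lower from compound 2 to compound 3 (within the scatter). The estimate for compound 3 is 5%, ranging from -5% to 15%.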

Compound 3, a percentage reported as inhibition, at one concentration (the size of the read-out at that concentration, not a potency): 0%
For compound 3 the middle estimate is 5 percentage points above the measured one; measured number inside the range.
By their numbers in this assay, from the lowest: compounds 1, 3 and 2 (each within the scatter of the next).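

In this assay, pyridin-2-yl in place of phenyl gives a number 6 percentage points lower from compound 2 to compound 3 (within the scatter) and, in place of methyl, no change at the digits printed from compound 1 to compound 3 (within the scatter) on the same aromatic carbon. Methyl, phenyl and pyridin-2-yl therefore cannot be told apart here, and a ring nitrogen in the new group brings no readable change. No supporting measurement offers an explanation for these numbers.

On these data alone, whether any group at this position can lift the inhibition clear of the scatter remains open. An amine, a carboxylic acid or a longer chain here would test that.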